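The source may report more compounds than this note shows. Statements on the series, on what has been measured and on what is new or still open speak of the compounds shown alone.

Working notes on the series. In a functional assay on the whole organism (strain Swiss) with Mus musculus as the target, in the maximal electroshock model, with a stated time of 2 h, at a dose of 100 mg/kg by the intraperitoneal route (on this read-out lower numbers stand for a weaker effect and higher numbers for a stronger effect at the one dose given), compound 1 `CCC(C(=O)N1CCN(c2cccc(Cl)c2)CC1)N1C(=O)CCC1=O` gives 0% and stands level with its two measured companions: compound 2 `CC(C(=O)N1CCN(c2ccccc2C(F)(F)F)CC1)N1C(=O)CCC1=O` gives 0% in this assay, and compound 3 `CC(C(=O)N1CCN(c2cccc(Cl)c2)CC1)N1C(=O)CCC1=O` gives 0%. Within the data shown here, the only single-place step recorded, no change at the digits printed from compound 1 to compound 3 (within the scatter), changes nothing beyond the scatter. Compound 4 `CCC(C(=O)N1CCN(c2ccccc2)CC1)N1C(=O)CCC1=O` is compound 1 with one alteration: hydrogen in place of chloro on an aromatic carbon. Among the measured compounds shown here, no recorded step touches the aromatic ring, so the measured steps bear on this change only in that every measured compound sits at the same level; compounds 2 and 3 carry different aryl substitution and show the same reading. The expectation is therefore no change at the digits printed from compound 1 to compound 4 (within the scatter), a step of no real size. Compound 4 is expected to give 0% in this assay, within 0% to 10%.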

Compound 4, a percentage reported as activity, at one dose (the size of the read-out at that dose, not a potency): 0%
For compound 4 middle estimate and measured number coincide at the digits printed; the range from low to high includes it.
By their numbers in this assay, from the lowest: compounds 1, 2, 3 and 4 (each within the scatter of the next).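

In this assay, among these compounds, the 3-chlorophenyl to phenyl change gives no change at the digits printed from compound 1 to compound 4 (within the scatter), the first recorded step on the aromatic ring. At this place on the ring, the reading therefore does not depend on the chloro group in this pair, though a reading at zero on both sides leaves no room to see a loss. Nothing available accounts for the flat reading. As far as these compounds go, whether a methoxy group or an amine at this place would lift the reading stays open. So does the effect of removing the chloro group from a compound that reads above zero.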